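Aryl in place of ester at the chain carbon

A few compounds are considered here, and "the series" means these few. Any claim that something is new, unique, unknown or untested is made for them only; others in the source may bear on it.

Measured compounds:
compound 1 `COC(=O)/C=C/c1cccc(N(Cc2ccc(/C=C/c3ccccc3F)cc2)C(=O)C2CCCCC2)c1`, 64 nM
compound 2 `COC(=O)/C=C/c1cccc(N(Cc2ccc(/C=C/c3cccc(F)c3)cc2)C(=O)C2CCCCC2)c1`, 86 nM
compound 3 `CCOC(=O)/C=C/c1ccc(CN(C(=O)C2CCCCC2)c2cccc(/C=C/C(=O)OC)c2)cc1`, > 1000 nM

In an assay on isolated protein with Bile acid receptor (Homo sapiens) as the target (on this read-out lower numbers stand for an effect already at smaller amounts and higher numbers for an effect only at larger amounts of compound), compound 1 gives 64 nM and compound 2 gives 86 nM, and the step of a 1.3-fold higher number from compound 1 to compound 2 (0.13 log units; within the scatter) stays within the scatter. For compound 3 this assay reports only a limit, > 1000 nM, so compound 3 sits at the limit of > 1000 nM in this assay, at which 1 of the 3 values shown sits, without a number of its own. Compound 4 `COC(=O)/C=C/c1cccc(N(Cc2ccc(/C=C/c3ccc(OC)cc3)cc2)C(=O)C2CCCCC2)c1` differs from compound 3 by 4-methoxyphenyl in place of ethoxycarbonyl on a double-bonded chain carbon bound to a double-bonded chain carbon. Going by the values given here, two measured steps bear on this change: an at least 15-fold higher number from compound 1 to compound 3 (1.19 log units; beyond the scatter) and an at least 11-fold higher number from compound 2 to compound 3 (1.06 log units; beyond the scatter), both of which replaced a fluorophenyl on that carbon by the ethoxycarbonyl and both went far beyond the scatter. Returning an aryl group to that carbon is therefore expected to lower the number by a large step, an at least 10-fold lower number from compound 3 to compound 4 (1.00 log units; beyond the scatter). Compound 4 is estimated at 100 nM, expected between 40 nM and 400 nM.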

Compound 4, half-maximal effective concentration: 208 nM
Compound 4: the middle estimate sits 2.1-fold (0.32 log units) below what was measured; the measured number falls inside the stated range.
By their numbers in this assay, from the lowest: compounds 1 and 2 (each within the scatter of the next); then compound 4. At a limit, above all of these: compound 3.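

In this assay, a third aryl group at this chain carbon also gives a lower number than the ethoxycarbonyl, an at least 4.8-fold lower number from compound 3 to compound 4 (0.68 log units; beyond the scatter), so the gain is not confined to the fluorophenyl compounds. Compound 3 has only a limit, not a number: the limit of > 1000 nM in this assay, at which 1 of the 4 values shown sits. The aryl ring alone does not settle the value, however, as 4-methoxyphenyl gives higher numbers than either fluorophenyl group, with a 2.4-fold higher number from compound 2 to compound 4 (0.38 log units; beyond the scatter) and a 3.3-fold higher number from compound 1 to compound 4 (0.51 log units; beyond the scatter).

The compounds shown do not separate the effect of the methoxy group from that of its place on the ring, as the substituent and its place both differ from those of the fluorophenyl groups. Open too, on these data alone, is how a 4-fluorophenyl, an unsubstituted phenyl or a pyridine ring would read at this carbon.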